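The source may report more compounds than this note shows. Statements on the series, on what has been measured and on what is new or still open speak of the compounds shown alone.

Measured in a functional assay on PC-3 cells (Homo sapiens) for cytotoxicity, read by MTT assay, with a stated time of 24 h; a higher number here means a weaker inhibitor, a lower number a stronger inhibitor:
- Compound 1 `Cc1ccc(/C=C2\CN(C(=S)SCc3cn(Cc4ccc(F)cc4)nn3)C/C(=C\c3ccc(C)cc3)C2=O)cc1`: 45500 nM
- Compound 2 `O=C1/C(=C/c2ccccc2F)CN(Cc2cn(Cc3ccccc3Cl)nn2)C/C1=C\c1ccccc1F`: 7100 nM

Of these two, compound 1 has the higher number, beyond the scatter of compound 2, so it is the weaker inhibitor. Compound 3 `Cc1ccc(/C=C2\CN(C(=S)SCc3cn(Cc4ccccc4Cl)nn3)C/C(=C\c3ccc(C)cc3)C2=O)cc1` keeps the core of compound 1 and carries 2-chlorophenyl in place of 4-fluorophenyl on a saturated chain carbon bound to an aromatic nitrogen. Among the compounds with values here, no measured step isolates this change. Compound 2 also carries 2-chlorobenzyl and gives 7100 nM, but it differs elsewhere too, so it is only a weak guide. A modest downward step is expected in this assay, estimated as a 1.5-fold lower number from compound 1 to compound 3 (0.18 log units; within the scatter). For compound 3 the expected value is 30000 nM, with an estimated range of 12000 nM to 70000 nM.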

Compound 3, half-maximal inhibitory concentration: > 80000 nM
Compound 3: no number, only a limit; the forecaster's own chance of this, stated with the estimate: 10%; middle value at least 2.6-fold (0.42 log units) from the limit.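

Within the data shown here, this is the first one-place change read at this position, on a saturated chain carbon bound to an aromatic nitrogen, and in this assay it gives an at least 1.7-fold higher number from compound 1 to compound 3 (0.24 log units; that floor lies within the scatter). That floor does not clear the usual scatter, but it shows that 2-chlorophenyl brings no strengthening on the core of compound 1. For compound 3 the reading is a limit, not a number: the limit of > 80000 nM in this assay, at which 1 of the 3 values shown sits.

The compounds shown leave open how far past that limit compound 3 lies. They also leave open how a plain phenyl, a pyridine ring or a longer chain ending in an amine would read at this position.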